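This account rests on a few compounds, and the source may have more. Where it says the series, first, only, none or still open, it means among the compounds named here.

Measured so far in a functional assay on MCF7 cells (Homo sapiens) for antiproliferative activity, read by sulforhodamine B assay, with a stated time of 48 h; on this read-out higher numbers stand for weaker inhibition and lower numbers for stronger inhibition:
compound 1 `O=C1NCCN1c1ccc(S(=O)(=O)Nc2ccc(I)cc2)cc1`: 600 nM
compound 2 `Cc1cc(C)cc(NS(=O)(=O)c2ccc(N3CCNC3=O)cc2)c1`: 100 nM

Of these two, compound 2 has the lower number, at 100 nM in this assay. Compound 3 `Cc1cccc(NS(=O)(=O)c2ccc(N3CCNC3=O)cc2)c1C` keeps the shared core and the sulfonamide. It differs from compound 2 only in the group on the sulfonamide nitrogen, with 2,3-dimethylphenyl in place of 3,5-dimethylphenyl on a sulfonamide nitrogen. The two groups have the same atoms, joined differently.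

Going by the values given here, one measured step bears on this change, and only indirectly. That step is a 6.0-fold lower number from compound 1 to compound 2 (0.78 log units; beyond the scatter), a modest one beyond the scatter, exchanging 4-iodophenyl for 3,5-dimethylphenyl at the same place. Among the compounds with values here, no measured compound carries 2,3-dimethylphenyl, so the data do not test this exchange directly. A clearly smaller change than that step is expected, probably none beyond the scatter. A slight lean towards a higher number rests only on compound 2 having 100 nM, the lower of the two values. The expected step is a 1.5-fold higher number from compound 2 to compound 3 (0.18 log units; within the scatter). The estimate for compound 3 is 150 nM, with an expected range of 50 nM to 500 nM.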

Compound 3, half-maximal inhibitory concentration: 230 nM
The estimate for compound 3 lay 1.5-fold (0.19 log units) below the measured number; the measured number falls inside the stated range.
By their numbers in this assay, from the lowest: compound 2; then compound 3; then compound 1.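

In this assay the result gives the first read on how the substituents are arranged at this position: 2,3-dimethylphenyl in place of 3,5-dimethylphenyl on a sulfonamide nitrogen gives a 2.3-fold higher number from compound 2 to compound 3 (0.36 log units; beyond the scatter). The two groups have the same atoms, so the arrangement of the two methyl groups alone moves the number beyond the scatter, and 3,5-dimethylphenyl holds the lowest number of the three aryl groups, while 2,3-dimethylphenyl in place of 4-iodophenyl still gives a 2.6-fold lower number from compound 1 to compound 3 (0.42 log units; beyond the scatter). Nothing on hand speaks to why the arrangement of the methyl groups changes the number.

Still open, on these data alone, is whether both methyl groups are needed, since a phenyl group carrying a single methyl, or an unsubstituted phenyl, would separate the effect of each methyl from that of the pair. Also open, as far as these compounds go, is whether the aryl group tolerates anything other than methyl or iodine, such as methoxy, an amine or a carboxylic acid, and whether the order of these three compounds holds on any change to the shared core.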